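Methoxy for fluoro on the isatin ring of compound 1

The source may hold more compounds than are shown below. What is called first, only, known or untested is meant among the compounds shown, and "the series" means these compounds.

Working notes on a coumarin-triazole-isatin series. Three compounds have numbers in a functional assay on COLO 205 cells (Homo sapiens) for inhibition, read by sulforhodamine B assay, with a stated time of 48 h, tested at 50 uM; on this read-out lower numbers stand for less inhibition of growth and higher numbers for more inhibition of growth at the one concentration tested: compound 1 `O=C1C(=O)N(CCCn2cc(COc3cc(=O)oc4ccccc34)nn2)c2ccc(F)cc21` gives 69%, compound 2 `O=C1C(=O)N(CCCCCn2cc(COc3cc(=O)oc4ccccc34)nn2)c2ccccc21` gives 62%, and compound 3 `O=C1C(=O)N(CCCCn2cc(COc3cc(=O)oc4ccccc34)nn2)c2ccc(Cl)cc21` gives 60%. Compound 1 stands at the top of these three numbers, but the gaps to compound 2 and to compound 3 both lie within the usual scatter, so the three cannot be separated on this read-out.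

Compound 4 `COc1ccc2c(c1)C(=O)C(=O)N2CCCn1cc(COc2cc(=O)oc3ccccc23)nn1` has not been measured. It differs from compound 1 by methoxy in place of fluoro on an aromatic carbon of the shared core. Within the data shown here, no pair of measured compounds shows this kind of change, so nothing here tells how large its effect is.

On the numbers shown, the step of a number 5 percentage points lower from compound 1 to compound 4 (within the scatter) is expected to stay within the scatter, since the three measured compounds sit close together despite different substituents and chain lengths. For compound 4 the expected value in this assay is 64%, with a range from 48% to 78%.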

Compound 4, percent growth inhibition at one concentration: 48%
Estimate against measurement, compound 4: 16 percentage points above; the range from low to high includes it.
By their numbers in this assay, from the lowest: compound 4; then compounds 3, 2 and 1 (each within the scatter of the next).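

Methoxy in place of fluoro on an aromatic carbon of the shared core is the first single change in this series with a readable effect: in this assay it gives a number 21 percentage points lower from compound 1 to compound 4 (beyond the scatter). The earlier compounds shown here could not be separated, so they gave no sign that a group at this place could move the read-out; this one pair shows that it can. No measured property of these compounds is at hand to account for the step.

From the compounds shown here alone, whether other groups at this place, such as an amine, a carboxylic acid or trifluoromethyl, would give a step of similar size remains open. Equally open, going by these compounds, is whether the same change from fluoro to methoxy would hold its size on a longer chain.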